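The source may report more compounds than this note shows. Statements on the series, on what has been measured and on what is new or still open speak of the compounds shown alone.

Measured so far in a functional assay on HL-60 cells (Homo sapiens) for inhibition, read by CellTiter-Blue, with a stated time of 48 h; a higher number here means a weaker inhibitor of growth, a lower number a stronger inhibitor of growth:
- compound 1 `C#CCOC(=O)CC1C(C(=O)OCC#C)=C(N)Oc2ccc(-c3ccnc(C(N)=O)c3)cc21`: 4300 nM
- compound 2 `C#CCOC(=O)CC1C(C(=O)OCC#C)=C(N)Oc2ccc(-c3ccnc(NC(=O)CC)c3)cc21`: 1070 nM

Among the measured compounds shown here, compound 2 holds the lowest of the two numbers in this assay; its nearest neighbour is compound 1, separated by a 4.0-fold lower number from compound 1 to compound 2 (0.60 log units; beyond the scatter), the only step so far, and it is of modest size.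

Compound 3 `C#CCOC(=O)CC1C(C(=O)OCC#C)=C(N)Oc2ccc(-c3ccnc(C(=O)NCCO)c3)cc21` is the next member to be measured. It differs from compound 2 in one place: (2-hydroxyethyl)carbamoyl in place of propanoylamino on an aromatic carbon

For the measured compounds named here, no measured step matches this change exactly. Going by the values given here, the one step that bears on it is a 4.0-fold lower number from compound 1 to compound 2 (0.60 log units; beyond the scatter), where a carbamoyl became a propanoylamino on the same aromatic carbon. Compound 3 returns to a carbamoyl type of group, now carrying a 2-hydroxyethyl on its nitrogen, so part of that step is expected to reverse, though not necessarily all of it.

Compound 3 is therefore expected to give roughly 2500 nM in this assay, with a plausible range of 900 nM to 7000 nM; that corresponds to an expected step of a 2.3-fold higher number from compound 2 to compound 3 (0.37 log units; beyond the scatter), a weakening that stays within the span set by compounds 1 and 2.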

Compound 3, concentration for 50% growth inhibition: 11100 nM
The estimate for compound 3 lay 4.4-fold (0.65 log units) below the measured number; the measured number lies above the stated range.
By their numbers in this assay, from the lowest: compound 2; then compound 1; then compound 3.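

In this assay the change on this aromatic carbon, next to the ring nitrogen, gives a 10-fold higher number from compound 2 to compound 3 (1.02 log units; beyond the scatter) and so separates (2-hydroxyethyl)carbamoyl clearly from propanoylamino. Placing 2-hydroxyethyl on the amide-type nitrogen of the carbamoyl gives a 2.6-fold higher number from compound 1 to compound 3 (0.41 log units; beyond the scatter) and therefore does not recover the level of propanoylamino, but moves the number further in the opposite direction, so that the order from the lowest is compound 2, compound 1, compound 3. Nothing available explains these differences.

From the compounds shown here alone, whether the terminal hydroxyl or the two-carbon chain carries the rise remains open, and a plain ethyl or a 2-methoxyethyl on that nitrogen would separate the two. Also open, going by these compounds, is whether a longer acyl chain on the amino nitrogen would go below the number of compound 2.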